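A few compounds are considered here, and "the series" means these few. Any claim that something is new, unique, unknown or untested is made for them only; others in the source may bear on it.

Measured compounds:
- compound 1, `COC(=O)Nc1cc(-c2ccc(OC[C@@](C)(N)CC(C)C)c(C)c2)ccn1`, 0.8 nM
- compound 2, `COC(=O)Nc1cc(-c2ccc(OC[C@@](C)(N)CC(C)C)nc2)ccn1`, 28 nM
- compound 3, `COC(=O)Nc1cc(-c2ccc(OC[C@@](C)(N)CC(C)C)c(C)c2C)ccn1`, 4.5 nM

All three values come from an assay on isolated protein for inhibition of AP2-associated protein kinase 1 (Homo sapiens), with a stated time of 3 h, in the presence of a further agent that is not named here; a higher number here means a weaker inhibitor, a lower number a stronger inhibitor. Compound 1 gives 0.8 nM and is the strongest inhibitor of the three. Compound 3 carries one more methyl than compound 1; the difference is methyl in place of hydrogen on an aromatic carbon and the step is a 5.6-fold higher number from compound 1 to compound 3 (0.75 log units; beyond the scatter). Compound 2 has a different core from compound 1; how the two cores differ is not broken down here. In this assay compound 2 gives 28 nM, the highest number of the three and well beyond the scatter from both others.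

Compound 4, `COC(=O)Nc1cc(-c2cnc(OC[C@@](C)(N)CC(C)C)cc2C)ccn1`, is not yet measured. It relates to compound 2 as compound 3 relates to compound 1: the difference is methyl in place of hydrogen on an aromatic carbon. It is the same kind of change, not the same change. In compound 3 the new methyl sits on a six-membered aromatic ring of carbon only, ortho to a methyl group; in compound 4 it sits on a six-membered aromatic ring with one nitrogen, opposite the ring nitrogen, with no methyl group noted around it.

Among the compounds with values here, for compound 4 in this assay the step from its parent is expected to be a 4.6-fold higher number from compound 2 to compound 4 (0.67 log units; beyond the scatter), of similar size to a 5.6-fold higher number from compound 1 to compound 3 (0.75 log units; beyond the scatter), since that is the only precedent for this kind of change and compound 2 starts from 28 nM. Within the data shown here, the estimate for compound 4 is therefore 130 nM, with a range of 40 nM to 400 nM, the range set wide because only one earlier step of this kind exists.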

Compound 4, half-maximal inhibitory concentration: 490 nM
Compound 4: middle estimate off by 3.8-fold (0.58 log units), on the low side; the measured number lies above the stated range.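

In this assay, methyl in place of hydrogen on an aromatic carbon gives an 18-fold higher number from compound 2 to compound 4 (1.24 log units; beyond the scatter). Set beside the earlier step, the direction carries over from one core to the other, but the size does not: the same change on two cores in this assay, a 5.6-fold higher number (0.75 log units; beyond the scatter) from compound 1 to compound 3 and an 18-fold higher number (1.24 log units; beyond the scatter) from compound 2 to compound 4, 3.1-fold (0.49 log units) apart, beyond the scatter of two such steps

This comparison rests on a single pair for each core, and it is the same kind of change rather than the same change: in compound 4 the methyl sits on a six-membered aromatic ring with 1 nitrogen, ortho to a large group and opposite the ring nitrogen, whereas in compound 3 it sits on a ring of carbon only; the data therefore cannot separate the effect of the core from that of the methyl's place, and they give no reason for the gap.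

As far as these compounds go, it remains open whether a methyl on the matching carbon of the core of compound 1 would give a step nearer the one seen on the core of compound 2, and whether other free aromatic carbons on either core would respond in the same direction. From the compounds shown here alone, it is also open whether a fluorine, a chlorine or a methoxy group in place of this methyl would follow the same course on the two cores.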